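The source may hold more compounds than are shown below. What is called first, only, known or untested is meant among the compounds shown, and "the series" means these compounds.

Compound 1 `C=CCc1cc(OC)c(OC(C)C(OCCOCCCC)c2ccc(O)c(OC)c2)c(OC)c1` is the reference point here. In an assay on HEK293 cells for agonist activity at transient receptor potential cation channel subfamily M member 8 (Homo sapiens), read by fluorescence and calcium flux, with a stated time of 5 min (on this read-out higher numbers stand for an effect only at larger amounts of compound and lower numbers for an effect already at smaller amounts), compound 1 gives 153 nM, the lowest of the two numbers that were obtained. Compound 3 `C=CCc1cc(OC)c(OC(C)C(OC)c2ccc(O)c(OC)c2)c(OC)c1` is its nearest neighbour; in this assay compound 3 gives 3450 nM, and the step from one to the other is a 23-fold higher number from compound 1 to compound 3 (1.35 log units; beyond the scatter). Compound 2 `C=CCc1cc(OC)c(O[C@H](C)[C@@H](OC(C)=O)c2ccc(O)c(OC)c2)c(OC)c1` stands apart: in this assay compound 2 reaches only > 10000 nM, a limit of the assay rather than a number, and the limit of > 10000 nM in this assay, at which 1 of the 3 values shown sits, is the single such result among the three.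

Compound 4 `C=CCc1cc(OC)c(OC(C)C(OCCCCCC)c2ccc(O)c(OC)c2)c(OC)c1` has not yet been measured. It differs from compound 1 in that (butyl in place of butoxy on a saturated chain carbon, two bonds along the chain from an oxygen on a saturated carbon). Among the compounds with values here, the one measured step that bears on this change, from compound 1 to compound 3, took away the whole butoxymethyl and produced a large shift; here the chain keeps its length and only the ether oxygen gives way to carbon. A much smaller step is therefore expected, likely within the scatter, and the expected step is a 1.3-fold higher number from compound 1 to compound 4 (0.12 log units; within the scatter). Compound 4 is estimated at 200 nM, within a range from 60 nM to 700 nM.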

Compound 4, half-maximal effective concentration: 329 nM
The estimate for compound 4 lay 1.6-fold (0.22 log units) below the measured number, and the stated range covers the measured number.
By their numbers in this assay, from the lowest: compound 1; then compound 4; then compound 3. At a limit, above all of these: compound 2.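

In this assay, changing butoxy to butyl gives a 2.2-fold higher number from compound 1 to compound 4 (0.33 log units; beyond the scatter) and so shows that the oxygen in this chain counts, although this step is only modest. Putting pentyl in place of hydrogen gives a 10-fold lower number from compound 3 to compound 4 (1.02 log units; beyond the scatter) and shows that a long chain made only of carbon still recovers most of what the shorter compound 3 lacks. At this place, then, the presence of the long chain matters more among these compounds than the ether oxygen within it.

From the compounds shown here alone, how far this gain extends remains open, as does the effect of a longer chain or of an amine or a carboxylic acid at the end of the chain. The data at hand give no reason for the modest step that the oxygen produces.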